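Phenyl substituent swap in the quinolinone enone series

This account rests on a few compounds, and the source may have more. Where it says the series, first, only, none or still open, it means among the compounds named here.

Compound 1 `COc1ccc(C(=O)/C=C/c2cc3ccccc3[nH]c2=O)cc1` carries a methoxy on the pendant phenyl ring. In an ADME assay on NCI-H226 cells (Homo sapiens) for cytotoxicity, read by sulforhodamine B assay, with a stated time of 24 h (a higher number here means that more compound is tolerated, a lower number that less compound is tolerated), compound 1 reaches only a limit, > 100000 nM. Among the compounds with values here, compound 2 `O=C(/C=C/c1cc2ccccc2[nH]c1=O)c1ccc(O)cc1` is the same core with the hydroxy in place of the methoxy; in this assay compound 2 gives 34500 nM, which is the only true number among the two values recorded, the other being (the limit of > 100000 nM in this assay, at which 1 of the 2 values shown sits). The step of an at least 2.8-fold lower number from compound 1 to compound 2 (0.46 log units; beyond the scatter) is therefore known only as a lower bound.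

Compound 3 `O=C(/C=C/c1cc2ccccc2[nH]c1=O)c1ccc(Cl)cc1` changes the same position again: chloro in place of hydroxy on an aromatic carbon. Within the data shown here, the only measured step that bears on it is the one from compound 1 to compound 2, which exchanged groups at the same carbon and shifted the number at least modestly. Compound 3 removes the donor and acceptor that compound 2 holds, so a shift back toward the value of compound 1 is plausible, but its size is uncertain. Compound 3 is therefore expected to give a somewhat higher number, a 1.7-fold higher number from compound 2 to compound 3 (0.24 log units; within the scatter), with the estimate for compound 3 at 60000 nM and a range from 20000 nM to 180000 nM.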

Compound 3, concentration lethal to 50% of the cells: > 100000 nM
Compound 3: a limit, no number (the forecaster's own chance of this, stated with the estimate: 30%); at least 1.6-fold (0.22 log units) between middle value and limit.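

Chloro in place of hydroxy on an aromatic carbon, para to a large group, gives an at least 2.8-fold higher number from compound 2 to compound 3 (0.46 log units; beyond the scatter), and this bound matches in size the one already seen on going from methoxy to hydroxy at the same carbon. Among the three compounds, the 4-hydroxyphenyl of compound 2 is thus the only group at this carbon that gives a true number in this assay, while the 4-chlorophenyl of compound 3 joins the methoxy of compound 1 at the top of the readable range: the limit of > 100000 nM in this assay, at which 2 of the 3 values shown sit. The step between those two compounds cannot be read, so the chloro and methoxy groups cannot be ranked against each other, and the true size of each step away from hydroxy also remains unknown.

The compounds shown leave open whether the hydroxy stands alone at this carbon or whether an amine or a carboxylic acid there would also give a true number. They also leave open whether a hydroxy moved elsewhere on the same aromatic ring would give a number like that of compound 2.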